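Fixing Two Stereocentres in a Permeability Series

A few compounds are considered here, and "the series" means these few. Any claim that something is new, unique, unknown or untested is made for them only; others in the source may bear on it.

In an ADME assay on Caco-2 cells (Homo sapiens) for permeability, read by LC-MS, in the apical to basolateral direction, with a stated time of 2 h (a lower number here means that the compound crosses the layer more slowly, a higher number that the compound crosses the layer faster), compound 1 `COc1cc(C(=O)N2CC[C@@H](O)C(C)(C)C2)cc2nc(NCc3cccc(Cl)c3)oc12` has no number, its entry reading "not determined" (no result reported). For the measured compounds named here, there, compound 2 `COc1cc(C(=O)N2CCC(O)C(C)C2)cc2nc(NCc3cccc(Cl)c3)oc12` gives 84 nm/s, the only number available, so it cannot yet be ranked against anything. Compound 3 `COc1cc(C(=O)N2CC[C@@H](O)[C@H](C)C2)cc2nc(NCc3cccc(Cl)c3)oc12` keeps the same atoms and bonds: the two compounds have the same atoms and bonds; at least one stereo element is drawn with a configuration in one of them and without one in the other: 2 of 2 stereo elements differ; a stereocentre at a saturated ring carbon is drawn without a configuration in compound 2 and R in compound 3; a stereocentre at a saturated ring carbon is drawn without a configuration in compound 2 and R in compound 3. Going by the values given here, no measured step shows what such a change does, so no step beyond the usual scatter is expected in this assay, in either direction. For compound 3 the estimated value is 85 nm/s, with an expected range from 40 nm/s to 170 nm/s.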

Compound 3, apparent permeability: 126 nm/s
Compound 3: the middle estimate sits 1.5-fold (0.17 log units) below what was measured, and the stated range covers the measured number.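

Setting both saturated ring carbons to R gives no clear shift in this assay, where the result is a 1.5-fold higher number from compound 2 to compound 3 (0.18 log units; within the scatter). For the compounds shown here, this is the first sign that a compound with these two stereocentres defined, compound 3, crosses the layer at a rate that cannot be told apart from that of compound 2. Even so, the step cannot be tied to any single configuration because of one limit on the comparison: the fact that one of compounds 2 and 3 is drawn with a defined configuration and the other without, at the place where they differ

Going by these compounds, the other configurations at these two carbons remain open. So does whether an amine in place of the hydroxyl would move the number beyond the usual scatter.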